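The source may report more compounds than this note shows. Statements on the series, on what has been measured and on what is new or still open speak of the compounds shown alone.

Of the compounds shown here, three that share one core have been measured in a functional assay on A549 cells (Homo sapiens) for antiproliferative activity, read by CCK-8 assay, with a stated time of 72 h; on this read-out lower numbers stand for stronger inhibition and higher numbers for weaker inhibition. Compound 1 `Cc1ccc(C(=O)Nc2cccc(-c3oc4cc(-c5ccc(F)cc5)ccc4c(=O)c3O)c2)cc1` gives 6910 nM in this assay. Compound 2 `O=C(Nc1cccc(-c2oc3cc(-c4ccc(F)cc4)ccc3c(=O)c2O)c1)c1ccc(F)cc1F` gives 20500 nM, and compound 3 `O=C(Nc1cccc(-c2oc3cc(-c4ccc(F)cc4)ccc3c(=O)c2O)c1)c1cccc(F)c1` gives 15400 nM. On these numbers compound 2 stands highest of the three: the step of a 3.0-fold higher number from compound 1 to compound 2 (0.47 log units; beyond the scatter) is the widest gap in the set, whereas the step of a 1.3-fold lower number from compound 2 to compound 3 (0.12 log units; within the scatter) lies within the scatter, so compound 2 and compound 3 cannot be told apart. The remaining step, a 2.2-fold higher number from compound 1 to compound 3 (0.35 log units; beyond the scatter), is modest.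

Compound 4 `O=C(Nc1cccc(-c2oc3cc(-c4ccc(F)cc4)ccc3c(=O)c2O)c1)c1ccc(Br)cc1F` differs from compound 2 in one place: bromo in place of fluoro on an aromatic carbon. No measured step swaps a bromo for a fluoro, so the only guidance comes from the three exchanges of the whole ring on the carbonyl carbon described above, which together span a modest range and show that varying substituents on that ring moves this assay by little more than the scatter. A single halogen exchange within the same ring, leaving the fluoro group in place, is therefore expected to produce a step no larger than that, and most likely none beyond the scatter. The step of a 1.4-fold lower number from compound 2 to compound 4 (0.14 log units; within the scatter) is estimated on this basis. Compound 4 is accordingly expected to give 15000 nM in this assay, within a range from 6000 nM to 40000 nM.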

Compound 4, half-maximal inhibitory concentration: 46100 nM
The estimate for compound 4 lay 3.1-fold (0.49 log units) below the measured number; measured number outside the range, above it.
By their numbers in this assay, from the lowest: compound 1; then compounds 3 and 2 (each within the scatter of the next); then compound 4.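

In this assay, bromo in place of fluoro on the aromatic carbon para to a large group and meta to a fluoro group gives a step beyond the scatter, a 2.2-fold higher number from compound 2 to compound 4 (0.35 log units; beyond the scatter), so exchanging this one atom moves the number as far as replacing 4-methylphenyl with 3-fluorophenyl does, a 2.2-fold higher number from compound 1 to compound 3 (0.35 log units; beyond the scatter). The 4-bromo-2-fluorophenyl group also widens the span of the set, with a 3.0-fold higher number from compound 3 to compound 4 (0.48 log units; beyond the scatter) and a 6.7-fold higher number from compound 1 to compound 4 (0.82 log units; beyond the scatter), and compound 4 is the weakest of the four, since its steps to all the others are beyond the scatter. No measurement to hand accounts for this rise.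

The compounds shown leave open whether the rise comes from bromo alone or depends on the fluoro group that stays in the ring, which a 4-bromophenyl group would help to separate. They also leave open how chloro, an amine or a carboxylic acid on the same carbon would compare with bromo and fluoro while the rest of compound 2 stays unchanged.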